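The compounds below may be only part of what the source reports. "The series", "measured", "known", "first", "only" and "open" are said of these compounds alone.

Of the compounds shown here, two have been measured in a functional assay on J82 cells (Homo sapiens) for cytotoxicity, read by colorimetric assay and MTT assay; a lower number here means a stronger inhibitor, a higher number a weaker inhibitor. Compound 1 (`CCN(CC)C(=O)Cn1c(=O)c(-c2ccc(OC)cc2)cc2c(OC)cc(OC)cc21`) gives 10000 nM, and compound 2 (`COc1ccc(-c2cc3c(OC)cc(OC)cc3n(CC(=O)OCc3ccccc3)c2=O)cc1`) gives 10000 nM, so compound 2 stands level with compound 1. Within the data shown here, the one measured step is no change at the digits printed from compound 1 to compound 2 (within the scatter), with benzyloxy in place of diethylamino on a carbonyl carbon.

The next compound is compound 3 (`CCN(CC)C(=O)CCn1c(=O)c(-c2ccc(OC)cc2)cc2c(OC)cc(OC)cc21`), and its difference from compound 2 is (diethylcarbamoyl)methyl in place of benzyloxycarbonyl on a saturated chain carbon bound to an aromatic nitrogen. In words, (diethylcarbamoyl)methyl stands in place of benzyloxycarbonyl on a saturated chain carbon bound to an aromatic nitrogen. Cut one bond further out, (benzyloxycarbonyl)methyl becomes 2-(diethylcarbamoyl)ethyl.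

Among the measured compounds shown here, compound 3 thus regains the diethylamino on a carbonyl carbon that compound 1 carries, and the only measured exchange of that kind is the step above, which showed no size beyond the scatter. For the measured compounds named here, no measured step speaks to the change from (benzyloxycarbonyl)methyl to 2-(diethylcarbamoyl)ethyl as a chain, so this evidence is thin. No shift beyond the scatter is expected in this assay, and neither direction is favoured. The expected outcome is no change at the digits printed from compound 2 to compound 3 (within the scatter). Compound 3 is estimated at 10000 nM, with an expected range of 4000 nM to 20000 nM.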

Compound 3, half-maximal inhibitory concentration: 10000 nM
For compound 3 middle estimate and measured number coincide at the digits printed, within the range that was stated.
By their numbers in this assay, from the lowest: compounds 1, 2 and 3 (each within the scatter of the next).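

In this assay, the step that extends the chain while also restoring the diethylamino on a carbonyl carbon gives no change at the digits printed from compound 2 to compound 3 (within the scatter), so the earlier exchange of end groups is now joined by a change in the chain itself, and no shift beyond the scatter appears. Taken alone, the added methylene unit, with (diethylcarbamoyl)methyl in place of diethylcarbamoyl, gives no change at the digits printed from compound 1 to compound 3 (within the scatter), the first direct reading of chain length at this place on a saturated chain carbon bound to an aromatic nitrogen. The material at hand offers no explanation for why these side chains read alike.

Going by these compounds, the three compounds share the same core and differ only in this side chain, so it remains open whether a carboxylic acid, a primary amine or a still longer chain at this place would give a value outside the scatter. On these data alone, it is equally open how the series would respond to a hydroxyl in place of a methoxy on the shared core, or to another group in place of the 4-methoxyphenyl.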